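From Compound 3 to Compound 4: Expecting Little Change

The source may report more compounds than this note shows. Statements on the series, on what has been measured and on what is new or still open speak of the compounds shown alone.

Of the compounds shown here, three that share a similar core have been measured so far. In an ADME assay on NHDF cells (Homo sapiens) for cytotoxicity, read by MTT assay, with a stated time of 72 h (a lower number here means a stronger inhibitor, a higher number a weaker inhibitor), compound 1 `COc1cccc(/C=C2\CCC/C(=C\c3cccc(Br)c3)C2=O)c1OC` gives 23900 nM, compound 2 `COc1cccc(/C=C2\CCC/C(=C\c3cccc(O)c3)C2=O)c1OC` gives 19300 nM and compound 3 `COc1ccc(/C=C2\CCC/C(=C\c3ccccc3Cl)C2=O)cc1OC` gives 21600 nM. These numbers all lie within the usual scatter of one another, so compound 3 cannot be ranked against the other two, and the three form a single level.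

The next compound, compound 4 `COc1ccc(/C=C2\CCC/C(=C\c3ccc(OC)c(OC)c3)C2=O)cc1`, differs from compound 3 at one place, with 4-methoxyphenyl in place of 2-chlorophenyl on a double-bonded chain carbon bound to a double-bonded ring carbon.

Among the compounds with values here, no measured step covers this exact swap. Within the data shown here, the only measured step that changes a single place is hydroxy in place of bromo on an aromatic carbon, a 1.2-fold lower number from compound 1 to compound 2 (0.09 log units; within the scatter), which stays within the scatter. Among the measured compounds shown here, it is a different change, so it offers only indirect guidance, but it is the sole evidence available, and it shows no sizeable shift.

No step beyond the scatter is therefore expected in this assay, and the estimated step is a 1.1-fold lower number from compound 3 to compound 4 (0.03 log units; within the scatter). For compound 4, the expected value is 20000 nM, with an estimated range from 9000 nM to 42000 nM.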

Compound 4, half-maximal inhibitory concentration: 30900 nM
The estimate for compound 4 lay 1.5-fold (0.19 log units) below the measured number; the measured number falls inside the stated range.
By their numbers in this assay, from the lowest: compounds 2, 3, 1 and 4 (each within the scatter of the next).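

In this assay, putting 4-methoxyphenyl in place of 2-chlorophenyl on a double-bonded chain carbon bound to a double-bonded ring carbon gives a 1.4-fold higher number from compound 3 to compound 4 (0.16 log units; within the scatter), so this position takes the exchange without a shift that can be told apart from the scatter. Within the data shown here, the earlier step changed only one small group on an aromatic carbon, whereas this one replaces a whole aromatic group: chlorine leaves, oxygen enters, and the count of hydrogen-bond acceptors in the exchanged group goes from 0 to 1, yet the step still stays within the scatter. No measurement is available that could explain why this larger exchange leaves the number within the scatter.

As far as these compounds go, whether a group of a different kind at this position, such as an amine, a carboxylic acid or a longer chain, would move the number beyond the scatter remains open. From the compounds shown here alone, it is equally open whether 4-methoxyphenyl would give a step of similar size if the rest of the molecule were different, since this exchange has been read only once, on the background of compound 3.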